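Carboxyphenyl variant of a diethylamino triazine series

A few compounds are considered here, and "the series" means these few. Any claim that something is new, unique, unknown or untested is made for them only; others in the source may bear on it.

Of the compounds shown here, three sharing one core have been measured in an assay on cells for activation of Cystic fibrosis transmembrane conductance regulator (Homo sapiens), read by fluorescence, with stated times of 10 min and 12 s; a higher number here means that more compound is needed for the effect, a lower number that less compound is needed. Compound 1 `CCN(CC)c1nc(Nc2cccc(C(=O)O)c2)nc(OC(C(F)(F)F)C(F)(F)F)n1` gives 160 nM; compound 2 `CCN(CC)c1nc(Nc2cccc(F)c2)nc(OC(C(F)(F)F)C(F)(F)F)n1` gives 140 nM; compound 3 `CCN(CC)c1nc(Nc2cccc([N+](=O)[O-])c2)nc(OC(C(F)(F)F)C(F)(F)F)n1` gives 200 nM. Compound 3 shows the highest of the three numbers, yet the steps of a 1.3-fold higher number from compound 1 to compound 3 (0.10 log units; within the scatter) and a 1.4-fold higher number from compound 2 to compound 3 (0.15 log units; within the scatter) both lie within the scatter, as does a 1.1-fold lower number from compound 1 to compound 2 (0.06 log units; within the scatter), so the three are indistinguishable in this assay.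

Compound 4 `CCN(CC)c1nc(Nc2ccc(C(=O)O)cc2)nc(OC(C(F)(F)F)C(F)(F)F)n1` carries the change (4-carboxyphenyl in place of 3-nitrophenyl on a nitrogen on an aromatic ring). Among the measured compounds shown here, two parts of the measured set bear on it: the carboxy-to-nitro exchange a 1.3-fold higher number from compound 1 to compound 3 (0.10 log units; within the scatter) says carboxy and nitro behave alike, and compound 1 already holds a carboxy group, though as 3-carboxyphenyl rather than 4-carboxyphenyl; no measured pair shows the effect of that shift. The expected step of a 1.1-fold lower number from compound 3 to compound 4 (0.02 log units; within the scatter) is therefore small and without clear direction. Compound 4 is estimated at 190 nM, with a range from 70 nM to 550 nM.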

Compound 4, half-maximal effective concentration: 900 nM
Compound 4: the middle estimate sits 4.7-fold (0.68 log units) below what was measured, outside the stated range (above it).
By their numbers in this assay, from the lowest: compounds 2, 1 and 3 (each within the scatter of the next); then compound 4.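

In this assay, moving the carboxy group from 3-carboxyphenyl to 4-carboxyphenyl on a nitrogen on an aromatic ring gives a 5.6-fold higher number from compound 1 to compound 4 (0.75 log units; beyond the scatter), so the arrangement of this ring matters even though the exchanges among the 3-substituted phenyl groups stayed within the scatter. Compound 4 also separates from the other two compounds, with a 4.5-fold higher number from compound 3 to compound 4 (0.65 log units; beyond the scatter) and a 6.4-fold higher number from compound 2 to compound 4 (0.81 log units; beyond the scatter), which places it apart from all three earlier compounds. Nothing available here accounts for this separation.

As far as these compounds go, whether the higher number follows the carboxy group of compound 4 specifically or would come with other groups in its place remains open. An amine or a methyl ester in place of that carboxy group would help to separate these two readings.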